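Double-bond geometry in a chlorinated pair

The compounds below may be only part of what the source reports. "The series", "measured", "known", "first", "only" and "open" are said of these compounds alone.

Measured so far:
compound 1 `O=C1/C(=C/c2ccncc2)C(c2ccccc2)Oc2ccccc21`: 900 nM
compound 2 `O=C1/C(=C\c2ccc(Cl)cc2)C(c2ccccc2)Oc2ccccc21`: > 1000000 nM (a limit, not a number)

Both results come from a functional assay on HL-60 cells (Homo sapiens) for cytotoxicity, read by MTT assay, with a stated time of 46 h; on this read-out lower numbers stand for stronger inhibition and higher numbers for weaker inhibition. For compound 2, only a limit is known: the limit of > 1000000 nM in this assay, at which 1 of the 2 values shown sits. Compound 1 gives a measured number, 900 nM.

The next compound is compound 3 `O=C1/C(=C/c2ccc(Cl)cc2)C(c2ccccc2)Oc2ccccc21`. Its difference from compound 2 is the two compounds have the same atoms and bonds; at least one stereo element is drawn with a configuration in one of them and without one in the other: 1 of 2 stereo elements differ; a double bond is drawn Z in compound 2 and E in compound 3. The two compounds have the same atoms and bonds, and a double bond is drawn Z in compound 2 and E in compound 3.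

A large step towards stronger inhibition, well beyond the scatter, is expected in this assay. This expectation leans on compound 1, which reaches 900 nM, and the estimate remains uncertain. The expected change is an at least 200-fold lower number from compound 2 to compound 3 (2.30 log units; beyond the scatter). For compound 3, the estimated value is 5000 nM, with an expected range of 800 nM to 60000 nM.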

Compound 3, half-maximal inhibitory concentration: 5800 nM
Beside the measured number, compound 3's estimate is 1.2-fold (0.06 log units) below it; the measured number falls inside the stated range.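

In this assay, with the 4-chlorophenyl group kept, the double-bond geometry alone separates a measurable value from a limit: the change from Z to E gives an at least 170-fold lower number from compound 2 to compound 3 (2.23 log units; beyond the scatter). Compound 2 has only a limit, and this step is therefore a bound rather than a measured size: the limit of > 1000000 nM in this assay, at which 1 of the 3 values shown sits. Replacing pyridin-4-yl with 4-chlorophenyl is a much smaller change at this position: a 6.4-fold higher number from compound 1 to compound 3 (0.81 log units; beyond the scatter).

As far as these compounds go, it remains open whether the same dependence on geometry holds with pyridin-4-yl, and whether a 4-methoxyphenyl or 4-aminophenyl group in this place would read closer to compound 1 or to compound 3. The reading of the geometry also remains tied to how the pair is drawn: the fact that one of compounds 2 and 3 is drawn with a defined configuration and the other without, at the place where they differ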